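Chloro-to-hydrogen step on the shared core, second instance

The source may report more compounds than this note shows. Statements on the series, on what has been measured and on what is new or still open speak of the compounds shown alone.

Compound 1 `ClCc1cccc(Cn2cnc3c(Cl)ncnc32)c1`, compound 2 `ClCc1ccc(Cn2cnc3nc(Cl)nc(Cl)c32)cc1` and compound 3 `ClCc1cccc(Cn2cnc3c(Cl)nc(Cl)nc32)c1` have been run in a functional assay on HOP-62 cells (Homo sapiens) for cytotoxicity, read by sulforhodamine B assay, with a stated time of 48 h; on this read-out lower numbers stand for stronger inhibition of growth and higher numbers for weaker inhibition of growth. In this assay compound 1 gives 5120 nM, compound 2 gives 3890 nM and compound 3 gives 4360 nM; all three numbers lie within the usual scatter of one another, so none of them is set apart. Compound 1 and compound 3 differ in one place hydrogen in place of chloro on an aromatic carbon and the measured step is a 1.2-fold higher number from compound 3 to compound 1 (0.07 log units; within the scatter). Compound 2 and compound 3 are built from the same atoms joined differently; the difference between the two cores is not broken down here. Compound 4 `ClCc1ccc(Cn2cnc3ncnc(Cl)c32)cc1` has not yet been measured in this assay. It differs from compound 2 by the same change (hydrogen in place of chloro on an aromatic carbon), the surroundings of the place being described in identical words in both cases. Going by the values given here, since the one measured instance of this change, a 1.2-fold higher number from compound 3 to compound 1 (0.07 log units; within the scatter), stayed within the scatter, the step is expected to be of like size, a 1.2-fold higher number from compound 2 to compound 4 (0.07 log units; within the scatter), resting on that single measured pair. Compound 4 is therefore estimated at 4600 nM in this assay, with an expected range from 2500 nM to 9000 nM.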

Compound 4, concentration for total growth inhibition: 3160 nM
For compound 4 the middle estimate is 1.5-fold (0.16 log units) above the measured one; low and high end bracket the measured number.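

In this assay, hydrogen in place of chloro on an aromatic carbon gives a step within the scatter on this second core as well, with a 1.2-fold lower number from compound 2 to compound 4 (0.09 log units; within the scatter). Set beside the earlier instance, the two steps do not differ: the same change on two cores in this assay, a 1.2-fold higher number (0.07 log units; within the scatter) from compound 3 to compound 1 and a 1.2-fold lower number (0.09 log units; within the scatter) from compound 2 to compound 4, 1.4-fold (0.16 log units) apart, within the scatter of two such steps. Within these two pairs the change therefore carries from one core to the other only as a step too small to read; the opposite directions of the two steps mean nothing, and the pairs do not show that the same would hold on other cores or in other cells.

Going by these compounds, it remains open how the number would respond if an amine, a methoxy group or a thioether stood in place of the remaining chloro group on the shared core. Also open, on these data alone, is whether the chloromethyl group, common to all four compounds, could give way to a hydroxymethyl or plain methyl group.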